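Urea series on the shared core: removing the piperidinyl group

The source may report more compounds than this note shows. Statements on the series, on what has been measured and on what is new or still open speak of the compounds shown alone.

Of the compounds shown here, two have numbers so far. Compound 1 `CNC(=O)c1cc(Oc2ccc3nc(NC(=O)c4ccc(Cl)cc4Cl)sc3c2)ccn1` gives 14% in a functional assay on SK-BR-3 cells (Homo sapiens) for inhibition, read by MTT assay, with a stated time of 2 days, tested at 10 uM; a higher number here means more inhibition of growth at the concentration tested, a lower number less inhibition of growth. Compound 2 `CNC(=O)c1cc(Oc2ccc3nc(NC(=O)Nc4ccc(C5CCN(C(C)C)CC5)cc4)sc3c2)ccn1` gives 45% in this assay, which is the highest of the two numbers; compound 1 stands a step lower, and that gap is beyond the scatter. Among the compounds with values here, no pair that differs in one place has been measured against each other.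

Compound 3 `CNC(=O)c1cc(Oc2ccc3nc(NC(=O)Nc4ccc(F)cc4)sc3c2)ccn1` has not been measured. It departs from compound 2 by fluoro in place of 1-isopropylpiperidin-4-yl on an aromatic carbon. Within the data shown here, no measured step covers such a change, so the expectation rests on the two numbers alone. Among the measured compounds shown here, the step from compound 2 to compound 3 in this assay is expected to be downward and beyond the scatter, about a number 20 percentage points lower from compound 2 to compound 3 (beyond the scatter), because compound 1 with its 14% is the lower of the two numbers measured so far. Compound 3 is therefore estimated at 25%, with a range from 8% to 45%.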

Compound 3, percent growth inhibition at one concentration: 14.2%
Estimate against measurement, compound 3: 10.8 percentage points above; measured number inside the range.
By their numbers in this assay, from the lowest: compounds 1 and 3 (each within the scatter of the next); then compound 2.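

In this assay, fluoro in place of 1-isopropylpiperidin-4-yl on the aromatic carbon gives a number 30.8 percentage points lower from compound 2 to compound 3 (beyond the scatter), so the growth inhibition seen with compound 2 depends on the group at this position and is not carried by the urea and the shared core alone. The change of (4-fluorophenyl)amino in place of 2,4-dichlorophenyl on the carbonyl carbon gives a number 0.2 percentage points higher from compound 1 to compound 3 (within the scatter), so with fluoro at this position the urea link alone does not separate compound 3 from compound 1. No measurement on hand explains either step.

As far as these compounds go, it remains open whether the isopropyl group, the ring nitrogen or the saturated ring itself matters; a piperidin-4-yl without the isopropyl group, a cyclohexyl group or a dimethylamino group would separate these. From the compounds shown here alone, it also remains open whether a chloro or methoxy group at this position reads as fluoro does.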